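The compounds below may be only part of what the source reports. "The series", "measured", "known", "first", "only" and "open" are said of these compounds alone.

Series notes, antiproliferative read-out. Compound 1 `COc1cccc(C(=O)/C=C/c2cc(Br)cc(OC)c2O)c1` and compound 2 `Cc1ccc(C(=O)/C=C/c2cc(Cl)ccc2O)cc1` have both been run in a functional assay on MCF7 cells (Homo sapiens) for antiproliferative activity, read by sulforhodamine B assay, with a stated time of 72 h, tested at 10 uM; on this read-out lower numbers stand for a stronger effect and higher numbers for a weaker effect at the one concentration tested. In this assay compound 1 gives 77.3%, and in this assay compound 2 gives 36.8%. Compound 2 therefore stands lowest of the two numbers available; its nearest neighbour is compound 1, whose number lies higher by a gap that is beyond the scatter. Going by the values given here, no pair of measured compounds differs in a single place, so the two values are only read side by side and no step is drawn from them.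

Compound 3 `Cc1ccc(C(=O)/C=C/c2cc(Br)ccc2O)cc1` has not yet been measured in this assay. Relative to compound 2 it differs as follows: bromo in place of chloro on an aromatic carbon. Nothing else in the structure is altered.

Expectation for compound 3: the step of a number 1.8 percentage points lower from compound 2 to compound 3 (within the scatter) is expected to be small, with no direction that would reach beyond the scatter. Compound 2 gives 36.8%. Among the compounds with values here, the exchange of chloro for bromo is the only change. Compound 3 is estimated at 35%, with a range from 20% to 55%.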

Compound 3, a percentage reported as activity, at one concentration (the size of the read-out at that concentration, not a potency): 27.3%
Compound 3: middle estimate off by 7.7 percentage points, on the high side; the measured number falls inside the stated range.
By their numbers in this assay, from the lowest: compounds 3 and 2 (each within the scatter of the next); then compound 1.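

Going by these compounds alone, the exchange of chloro for bromo supplies the first single-place comparison: in this assay it gives a number 9.5 percentage points lower from compound 2 to compound 3 (within the scatter). At this place, on an aromatic carbon para to a hydroxy group and meta to a large group, the two halogens therefore cannot be told apart on this read-out, and the replacement of one heavy atom by another, with no change in the counted hydrogen-bond donors, hydrogen-bond acceptors or net charge, leaves the result within the usual variation between repeats. Nothing available explains the result or bears on how this position acts on the read-out.

Going by these compounds, whether the tolerance seen here extends beyond the two halogens remains open, since an amine, a carboxylic acid or a nitrile at the same place could give a step of a quite different size. Also open, on these data alone, is whether the exchange of chloro for bromo would stay within the scatter on a core with other substituents, or whether the result holds only for the core shared by compound 2 and compound 3.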